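The source may report more compounds than this note shows. Statements on the series, on what has been measured and on what is new or still open speak of the compounds shown alone.

Two compounds of the series have so far been run in a toxicity assay on the whole organism (J774 cells) for cytotoxicity, with Mus musculus as the target, read by MTT assay, with a stated time of 24 h, tested at 10 uM; a lower number here means a stronger effect, a higher number a weaker effect of the compound at the concentration tested. Compound 1 `CCCCCCCCCO[C@@H]1[C@@H](N)[C@@H](OCC(O)CNCCCN)O[C@H](CN)[C@H]1OCCCCCCCCC` gives 101% in this assay. Compound 2 `C=CCO[C@H]1O[C@H](CN)[C@@H](OCCCc2ccc3ccccc3c2)[C@H](OCCCc2ccc3ccccc3c2)[C@H]1N` gives 105% in this assay; the two numbers lie within the scatter of each other, so neither stands apart. Among the compounds with values here, no step between measured compounds that differ in one place is available. Compound 3 `CCCCCCCCCO[C@@H]1[C@@H](N)[C@@H](OC[C@H](O)CN)O[C@H](CN)[C@H]1OCCCCCCCCC` is not yet measured. It differs from compound 1 as follows: 2-amino-1-hydroxyethyl in place of 2-((3-aminopropyl)amino)-1-hydroxyethyl on a saturated chain carbon bound to an oxygen on a saturated carbon. Given compound 1 at 101% and compound 2 at 105%, no step beyond the scatter is expected in this assay. The expected step reads a number 1 percentage points lower from compound 1 to compound 3 (within the scatter). Compound 3 is estimated at 100%, with a range from 88% to 112%.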

Compound 3, a percentage reported as activity, at one concentration (the size of the read-out at that concentration, not a potency): 88%
Beside the measured number, compound 3's estimate is 12 percentage points above it, and the stated range covers the measured number.
By their numbers in this assay, from the lowest: compound 3; then compounds 1 and 2 (each within the scatter of the next).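

In this assay, within the data shown here, 3-amino-2-hydroxypropyl in place of 3-((3-aminopropyl)amino)-2-hydroxypropyl gives a number 13 percentage points lower from compound 1 to compound 3 (beyond the scatter) and is the first change at one place that can be read. The read-out at this position therefore responds to a change in this side chain. Nothing measured here accounts for the step.

Still open, going by these compounds, is whether a longer chain or a carboxylic acid in place of 3-amino-2-hydroxypropyl would move the number. The compounds shown also leave the defined stereocentre in compound 3 unseparated from the change in chain.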